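Fluoro for chloro on the azetidine carboxamide core

This account rests on a few compounds, and the source may have more. Where it says the series, first, only, none or still open, it means among the compounds named here.

Going by the values given here, the account follows compound 1, `NC(=O)[C@@H]1CCN1Cc1ccc(OCc2cccc(F)c2)cc1Cl`, and the single change that leads from it to compound 4, `NC(=O)[C@@H]1CCN1Cc1ccc(OCc2cccc(F)c2)cc1F`. In an assay on Sf9 cells for inhibition of Amine oxidase [flavin-containing] A (Homo sapiens), with stated times of 15 min and 60 min (a lower number here means a stronger inhibitor, a higher number a weaker inhibitor), compound 1 gives 2130 nM, the lowest of the two numbers shown. Compound 3, `CC1(C)C[C@@H](C(N)=O)N(Cc2ccc(OCc3cccc(F)c3)cc2)C1`, gives 17500 nM in this assay, a gap to compound 1 that lies beyond the scatter. For compound 2, `NC(=O)C1CN(Cc2ccc(OCc3cccc(F)c3)cc2)C1`, this assay reports only a limit, > 10000 nM, and not a number; (the limit of > 10000 nM in this assay, at which 1 of the 3 values shown sits).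

Compound 4 differs from compound 1 in one place: fluoro in place of chloro on an aromatic carbon. Among the compounds with values here, no measured pair in this set carries a change of this kind, so no step size is known from the data. The change swaps one halogen for another on the same aromatic carbon, and the author expects the step of a 1.4-fold higher number from compound 1 to compound 4 (0.15 log units; within the scatter) to be small, at most at the edge of the scatter, with a slight lean towards a weaker inhibitor. Compound 4 is therefore estimated to give 3000 nM in this assay, within a range from 1000 nM to 9000 nM.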

Compound 4, half-maximal inhibitory concentration: 18600 nM
Estimate against measurement, compound 4: 6.2-fold (0.79 log units) below; the whole stated range lies below it.
By their numbers in this assay, from the lowest: compound 1; then compounds 3 and 4 (each within the scatter of the next).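

In this assay, placing fluoro where compound 1 carries chloro, on the aromatic carbon ortho to the (2-carbamoylazetidin-1-yl)methyl group, gives an 8.7-fold higher number from compound 1 to compound 4 (0.94 log units; beyond the scatter). Going by these compounds alone, this is the first step measured at this position, and it shows that exchanging one halogen atom for another, with no ring, hydrogen-bond donor, hydrogen-bond acceptor or net charge entering or leaving, is enough to carry the number beyond the scatter. Nothing measured here accounts for the size of this step.

On these data alone, with only chloro and fluoro compared on this core, it remains open whether the number follows a trend across the halogens or whether chloro is favoured over other groups, such as bromo, methyl or methoxy, on the same carbon. As far as these compounds go, it is also open whether the step would hold on a different core.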